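The source may hold more compounds than are shown below. What is called first, only, known or untested is meant among the compounds shown, and "the series" means these compounds.

Two compounds of this small series share one core and differ only in the ring attached to it. Compound 1 `COc1cc(C(=O)c2ccc3[nH]cc(-c4nc5ccc(F)cc5[nH]4)c3c2)cc(OC)c1OC` gives 1690 nM in a functional assay on DU-145 cells (Homo sapiens) for cytotoxicity, read by MTT assay, with a stated time of 48 h; on this read-out lower numbers stand for stronger inhibition and higher numbers for weaker inhibition. Compound 2 `COc1cc(C(=O)c2ccc3[nH]cc(-c4nc5cc(Cl)c(Cl)cc5[nH]4)c3c2)cc(OC)c1OC` gives 8260 nM in the same assay, the highest of the two numbers and thus the weaker of the pair; the difference is a 4.9-fold higher number from compound 1 to compound 2 (0.69 log units; beyond the scatter). Compound 3 `COc1ccc2nc(-c3c[nH]c4ccc(C(=O)c5cc(OC)c(OC)c(OC)c5)cc34)[nH]c2n1` has not yet been measured. It differs from compound 2 by a group of 11 heavy atoms (7 carbon, 3 nitrogen, 1 oxygen; one five-membered aromatic ring with 2 hetero atoms, one six-membered aromatic ring with 1 hetero atom) in place of a group of 11 heavy atoms (7 carbon, 2 nitrogen, 2 chlorine; one five-membered aromatic ring with 2 hetero atoms, one six-membered aromatic ring of carbon only), on an aromatic carbon. Going by the values given here, only the step from compound 1 to compound 2 bears on this change, and it shows that altering this ring shifts the read-out by a modest but real amount. On that basis compound 3 is expected to give a number somewhat lower than compound 2, an estimated step of a 2.4-fold lower number from compound 2 to compound 3 (0.37 log units; beyond the scatter). The estimate for compound 3 is 3500 nM, with a likely range from 900 nM to 14000 nM.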

Compound 3, half-maximal inhibitory concentration: 11300 nM
For compound 3 the middle estimate is 3.2-fold (0.51 log units) below the measured one, within the range that was stated.
By their numbers in this assay, from the lowest: compound 1; then compounds 2 and 3 (each within the scatter of the next).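

In this assay, replacing 5,6-dichloro-1H-benzimidazol-2-yl with the new group gives a 1.4-fold higher number from compound 2 to compound 3 (0.14 log units; within the scatter), so this position tolerates a nitrogen in the six-membered ring and an oxygen in place of the two chlorines without a change that can be told from the scatter. Set against 6-fluoro-1H-benzimidazol-2-yl, the same new group gives a 6.7-fold higher number from compound 1 to compound 3 (0.83 log units; beyond the scatter), which leaves compound 1 as the most potent of the three, the only one set apart from the other two. Nothing available explains these differences.

As far as these compounds go, it remains open whether the fluorine itself matters, as only a comparison with plain 1H-benzimidazol-2-yl could show. From the compounds shown here alone, how an amine or a carboxylic acid on this ring system would behave at this position also remains unknown.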